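Ethyl in place of methoxy: what to expect

A few compounds are considered here, and "the series" means these few. Any claim that something is new, unique, unknown or untested is made for them only; others in the source may bear on it.

Values so far in a functional assay on 786-0 cells (Homo sapiens) for inhibition, read by sulforhodamine B assay, with a stated time of 48 h; on this read-out higher numbers stand for weaker inhibition of growth and lower numbers for stronger inhibition of growth
- Compound 1 `S=C(N/N=C/c1cccs1)Nc1ccccc1` gives 50400 nM
- Compound 2 `COc1ccc(NC(=S)N/N=C/c2cccs2)cc1` gives > 100000 nM, which is a limit of the assay and not a number

Compound 2 has no exact position on the scale, only the limit > 100000 nM. Compound 3 `CCc1ccc(NC(=S)N/N=C/c2cccs2)cc1` differs from it by ethyl in place of methoxy on an aromatic carbon, para to a large group, and the count of that change reads (ethyl in place of methoxy on an aromatic carbon). Within the data shown here, only one measured step bears on this change, namely methoxy in place of hydrogen on an aromatic carbon, which gave an at least 1.9-fold higher number from compound 1 to compound 2 (0.29 log units; that floor lies within the scatter). Nothing has yet been measured with ethyl at this carbon, so that step offers only an indirect guide. No step beyond the scatter is therefore expected in this assay, in either direction. Among the measured compounds shown here, compound 1 at 50400 nM provides the only exact number, so the expectation is anchored on it. Compound 2, with its limit > 100000 nM, is the other anchor. The estimated step is an at least 1.4-fold lower number from compound 2 to compound 3 (0.15 log units; that floor lies within the scatter), and it is uncertain because it starts from a limit. Compound 3 is expected at about 70000 nM, with an estimated range from 30000 nM to 140000 nM.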

Compound 3, concentration for 50% growth inhibition: 82600 nM
Compound 3: the middle estimate sits 1.2-fold (0.07 log units) below what was measured; low and high end bracket the measured number.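

Among these compounds, compound 3 is the first compound with a group on this aromatic carbon, para to a large group, to give an exact number in this assay, so a substituted compound at this position can now be placed on the scale. Set against the compound with hydrogen at this carbon, the result is a 1.6-fold higher number from compound 1 to compound 3 (0.21 log units; within the scatter), which shows that an ethyl group here is tolerated without a step beyond the scatter. The change from methoxy to ethyl is an at least 1.2-fold lower number from compound 2 to compound 3 (0.08 log units; that floor lies within the scatter), and this is only a floor, because compound 2 carries a limit of the assay and not a number: the limit of > 100000 nM in this assay, at which 1 of the 3 values shown sits.

Going by these compounds, whether an amine, a carboxylic acid or a longer chain such as butyl on this carbon would produce a step beyond the scatter, in either direction, remains open. Also open, on these data alone, is whether changes elsewhere on the shared core, rather than at this carbon, would move the number further than ethyl or methoxy have done here.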